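A few compounds are considered here, and "the series" means these few. Any claim that something is new, unique, unknown or untested is made for them only; others in the source may bear on it.

Working notes on the series, step from compound 3 to compound 4.

Within the data shown here, the three measured members share one core and differ only in the group on the amide-type nitrogen. Compound 1 `CNC(=O)[C@H](c1ccc(Cl)cc1)C(C)C` gives 11000 nM in a functional assay on CHO cells for agonist activity at Free fatty acid receptor 2 (Homo sapiens), read by cAMP accumulation; a higher number here means a weaker inhibitor, a lower number a stronger inhibitor. Compound 2 `CC(C)[C@H](C(=O)Nc1ncns1)c1ccc(Cl)cc1` gives 2000 nM in this assay, and compound 3 `CC(C)[C@H](C(=O)NC1=NC(=O)CS1)c1ccc(Cl)cc1` gives 20000 nM. Compound 3 therefore stands at the highest number of the three: its gap to compound 1 is within the scatter, while the step of a 10-fold higher number from compound 2 to compound 3 (1.00 log units; beyond the scatter) is beyond it.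

Compound 4 `Cc1csc(NC(=O)[C@H](c2ccc(Cl)cc2)C(C)C)n1` carries the change (a group of 6 heavy atoms (4 carbon, 1 nitrogen, 1 sulfur; one five-membered aromatic ring with 2 hetero atoms) in place of a group of 6 heavy atoms (3 carbon, 1 nitrogen, 1 oxygen, 1 sulfur; one five-membered non-aromatic ring with 2 hetero atoms), on an amide-type nitrogen). Among the measured compounds shown here, two measured steps bear on this. The step of a 10-fold higher number from compound 2 to compound 3 (1.00 log units; beyond the scatter) shows that exchanging a five-membered aromatic ring on the amide-type nitrogen for the non-aromatic ring of compound 3 raised the number clearly; the present change runs the other way, back to a five-membered aromatic ring. The step of a 5.5-fold lower number from compound 1 to compound 2 (0.74 log units; beyond the scatter) shows that a five-membered aromatic ring on that nitrogen also gave a lower number than methyl. Both point toward a lower number for compound 4 in this assay, of a size comparable to the return from compound 3 toward compound 2.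

Compound 4 is thus expected to give 2500 nM in this assay, within 800 nM to 8000 nM, which would mean an estimated step of an 8.0-fold lower number from compound 3 to compound 4 (0.90 log units; beyond the scatter).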

Compound 4, half-maximal inhibitory concentration: 1400 nM
Beside the measured number, compound 4's estimate is 1.8-fold (0.25 log units) above it, within the range that was stated.
By their numbers in this assay, from the lowest: compounds 4 and 2 (each within the scatter of the next); then compounds 1 and 3 (each within the scatter of the next).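

In this assay, 4-methyl-1,3-thiazol-2-yl in place of the non-aromatic ring on the amide-type nitrogen gives a 14-fold lower number from compound 3 to compound 4 (1.15 log units; beyond the scatter), so at this position a low number is no longer tied to the 1,2,4-thiadiazol-5-yl of compound 2 alone. The same group in place of methyl gives a 7.9-fold lower number from compound 1 to compound 4 (0.90 log units; beyond the scatter), while the exchange of one aromatic ring for the other gives a 1.4-fold lower number from compound 2 to compound 4 (0.15 log units; within the scatter), which leaves the two aromatic groups not distinguishable in this assay and both lower in number than methyl and the non-aromatic ring of compound 3. No measurement is available here that would account for these differences.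

The compounds shown leave open how much of the result belongs to the ring and how much to its methyl; the same ring without the methyl, or with an ethyl or a carboxylic acid in its place, would separate the two. Also open, on these data alone, is how far the result carries over to other groups on that nitrogen, such as a phenyl ring or a six-membered ring such as pyridin-2-yl, with the shared core unchanged.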